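Chloro to bromo on a weakly cytotoxic series

The source may hold more compounds than are shown below. What is called first, only, known or untested is meant among the compounds shown, and "the series" means these compounds.

Measured so far in a functional assay on MCF7 cells (Homo sapiens) for cytotoxicity, read by MTT assay, with a stated time of 72 h; on this read-out lower numbers stand for stronger inhibition and higher numbers for weaker inhibition:
- compound 1 `O=C1C(=Cc2ccc(O)cc2)C(=O)N(c2ccc(Cl)cc2)N1c1ccc(Cl)cc1` gives 23200 nM here
- compound 2 `O=C1C(=Cc2ccc(F)cc2)C(=O)N(c2ccc(Cl)cc2)N1c1ccc(Cl)cc1` gives 31400 nM here
- compound 3 `O=C1C(=Cc2ccc(Cl)cc2)C(=O)N(c2ccc(Cl)cc2)N1c1ccc(Cl)cc1` gives 28500 nM here

These three compounds share a core and differ in one group on an aromatic carbon. Compound 3 cannot be ranked against the other two, since its values sit within the ordinary scatter of repeat measurements. Exchanging fluoro for chloro gives a 1.1-fold lower number from compound 2 to compound 3 (0.04 log units; within the scatter) in this series, and exchanging hydroxy for chloro gives a 1.2-fold higher number from compound 1 to compound 3 (0.09 log units; within the scatter) on the same carbon.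

Compound 4 `O=C1C(=Cc2ccc(Br)cc2)C(=O)N(c2ccc(Cl)cc2)N1c1ccc(Cl)cc1` changes that same group once more: bromo in place of chloro on an aromatic carbon (bromo in place of chloro on an aromatic carbon, para to a large group). Within the data shown here, no bromo compound has been measured yet, so the closest guide is the other halogen exchange, a 1.1-fold lower number from compound 2 to compound 3 (0.04 log units; within the scatter) step already seen. The exchange of hydroxy for fluoro, with a 1.4-fold higher number from compound 1 to compound 2 (0.13 log units; within the scatter) as its result, points the same way. All three exchanges stayed within the scatter, so no clear shift in either direction is expected in this assay from this swap.

The estimated change is a 1.0-fold lower number from compound 3 to compound 4 (0.01 log units; within the scatter) in this read-out. Compound 4 is expected to give about 28000 nM, with a likely range from 16000 nM to 46000 nM in this assay.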

Compound 4, half-maximal inhibitory concentration: 30400 nM
Compound 4: the middle estimate sits 1.1-fold (0.04 log units) below what was measured; measured number inside the range.
By their numbers in this assay, from the lowest: compounds 1, 3, 4 and 2 (each within the scatter of the next).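

Bromo is the fourth group seen on this aromatic carbon, para to a large group, and in this assay it too fails to separate from the others: the steps read a 1.1-fold higher number from compound 3 to compound 4 (0.03 log units; within the scatter), a 1.0-fold lower number from compound 2 to compound 4 (0.01 log units; within the scatter) and a 1.3-fold higher number from compound 1 to compound 4 (0.12 log units; within the scatter). Together with the earlier steps, this means that no exchange among hydroxy, fluoro, chloro and bromo at this position has produced a difference larger than the ordinary variation between repeat measurements, so these four compounds cannot be ranked in this assay. The flat result is an observation only, and no supporting measurement is available to explain it.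

The compounds shown leave open whether a clearly different group on this same carbon, such as an amine, a carboxylic acid or a longer chain, would move the number beyond the scatter. They also leave open whether replacing the chloro groups elsewhere on the shared core would change the cytotoxicity read-out, since all four compounds carry those groups unchanged.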